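Dichlorophenyl Pattern in a Serotonin Receptor Binding Series

The source may report more compounds than this note shows. Statements on the series, on what has been measured and on what is new or still open speak of the compounds shown alone.

Measured compounds:
- compound 1 `CN1CCN(c2nc(N)nc(CCCOc3ccc(Cl)c(Cl)c3)n2)CC1`: 4880 nM
- compound 2 `CN1CCN(c2nc(N)nc(CCCOc3ccc(Cl)cc3Cl)n2)CC1`: 1940 nM
- compound 3 `CN1CCN(c2nc(N)nc(CCCOc3cc(Cl)ccc3Cl)n2)CC1`: 7920 nM

All three share one core and differ only in the dichlorophenyl carried on an oxygen on a saturated carbon. In an assay on HEK293 cells for displacement of a labelled ligand from 5-hydroxytryptamine receptor 7 (Homo sapiens), read by scintillation counting, with a stated time of 1 h (a higher number here means a weaker inhibitor, a lower number a stronger inhibitor), compound 3 gives the highest number of the three: one of the steps leading to it is a 1.6-fold higher number from compound 1 to compound 3 (0.21 log units; within the scatter), while the other is a 4.1-fold higher number from compound 2 to compound 3 (0.61 log units; beyond the scatter). Compound 2 also sits apart from compound 1 by a 2.5-fold lower number from compound 1 to compound 2 (0.40 log units; beyond the scatter), so the chlorine pattern on this ring moves the number over a modest span.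

Compound 4 `CN1CCN(c2nc(N)nc(CCCOc3cccc(Cl)c3Cl)n2)CC1` has not been measured. It differs from compound 3 as follows: 2,3-dichlorophenyl in place of 2,5-dichlorophenyl on an oxygen on a saturated carbon. For the measured compounds named here, the steps that bear on it are those among compounds 1, 2 and 3, and they are all modest or within the scatter. Going by the values given here, no measured step covers this exact change. Since compound 3 stands at the high end of a narrow spread, compound 4 is expected to give a number near or somewhat below it, a step of about a 1.6-fold lower number from compound 3 to compound 4 (0.20 log units; within the scatter), without confidence beyond the scatter. The estimate for compound 4 in this assay is 5000 nM, with a range from 1800 nM to 14000 nM.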

Compound 4, inhibition constant: 8590 nM
For compound 4 the middle estimate is 1.7-fold (0.24 log units) below the measured one; low and high end bracket the measured number.
By their numbers in this assay, from the lowest: compound 2; then compounds 1, 3 and 4 (each within the scatter of the next).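

In this assay, the 2,3-dichlorophenyl group on this oxygen cannot be told apart from the 2,5-dichlorophenyl group, with a 1.1-fold higher number from compound 3 to compound 4 (0.04 log units; within the scatter), or from the 3,4-dichlorophenyl group, with a 1.8-fold higher number from compound 1 to compound 4 (0.25 log units; within the scatter). The 2,4-dichlorophenyl group alone stands apart, with a 4.4-fold higher number from compound 2 to compound 4 (0.65 log units; beyond the scatter), which makes compound 2 the strongest inhibitor of the four and leaves compounds 1, 3 and 4 as one group within the scatter. No supporting data are available to explain this difference among the chlorine patterns.

Going by these compounds, it remains open whether the standing of the 2,4-dichlorophenyl group needs both chlorines, or whether a single chlorine or a difluorophenyl group would match it. Also open, on these data alone, is whether that group keeps its standing on a longer chain.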